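From ethoxy to phenoxy on a shared core

This account rests on a few compounds, and the source may have more. Where it says the series, first, only, none or still open, it means among the compounds named here.

Compound 3 `CCOc1ccccc1-c1nc2ccncc2s1` is the starting point here. In an ADME assay on Vero cells (Chlorocebus sabaeus) for cytotoxicity (a higher number here means that more compound is tolerated, a lower number that less compound is tolerated), compound 3 gives > 50000 nM as a limit, not a number. Its close relative compound 2 `COc1ccccc1-c1nc2ccncc2s1` gives > 50000 nM as a limit too. Compound 1 `c1ccc(Oc2ccccc2-c2nn3cnnc3s2)cc1`, built on a different core, gives > 50000 nM as a limit as well. The whole record so far comes down to the limit of > 50000 nM in this assay, at which 3 of the 3 values shown sit, and holds no exact number.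

The change to compound 4 `c1ccc(Oc2ccccc2-c2nc3ccncc3s2)cc1` is phenyl in place of ethyl on an oxygen on an aromatic ring and in words it is phenyl in place of ethyl on an oxygen on an aromatic ring, so ethoxy becomes phenoxy while the core stays the same. Within the data shown here, only one measured step touches this side chain, and it is a step that the two limits leave unreadable from compound 2 to compound 3 so it offers no size to carry over. Some guidance comes from compound 1, which already carries a phenoxy group and reads > 50000 nM as a limit on its own core. In this assay the expected outcome is a number no higher from compound 3 to compound 4 (the limit leaves the size open) with no clear direction beyond the scatter, and another limit is the likeliest report. Compound 4 is estimated at 50000 nM with an expected range from 20000 nM to 100000 nM on this thin evidence.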

Compound 4, half-maximal cytotoxic concentration: > 50000 nM
Compound 4 gave a limit, no number; the forecaster's own chance of this, stated with the estimate: 70%; the middle value lies on the limit itself.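

In this assay compound 4 gives > 50000 nM as a limit, not a number. The steps from compound 2 and from compound 3 to compound 4 each join two limits, so neither can be read. The compounds shown leave open how much of any of them the cells tolerate, and whether changing the group on the oxygen alters that at all.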